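Cyano in place of bromo: compound 3 to compound 4

The source may hold more compounds than are shown below. What is called first, only, known or untested is meant among the compounds shown, and "the series" means these compounds.

Within the data shown here, compound 3 `COc1cccc([C@H](c2cc3cc(Br)ccc3nc2OC)[C@@](O)(CCN(C)C)c2cc(SC)nc(SC)c2)c1F` gives 17 uL/min in an ADME assay on microsomes from liver (Mus musculus) for metabolic stability (on this read-out lower numbers stand for slow clearance and higher numbers for fast clearance), the second highest of the three numbers so far. Compound 1 `CCOc1cc([C@](O)(CCN(C)C)[C@@H](c2cc3cc(Br)ccc3nc2OC)c2cccc(OC)c2F)cc(OC)n1` gives 14 uL/min, and the step of a 1.2-fold higher number from compound 1 to compound 3 (0.08 log units; within the scatter) lies within the scatter. Compound 2 `COc1cc([C@](O)(CCN(C)C)[C@@H](c2cc3cc(C#N)ccc3nc2OC)c2cccc(OC)c2F)cc(SC)n1` gives 36 uL/min, which stands beyond the scatter from compound 3.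

Compound 4 `COc1cccc([C@H](c2cc3cc(C#N)ccc3nc2OC)[C@@](O)(CCN(C)C)c2cc(SC)nc(SC)c2)c1F` is not yet measured. Its change from compound 3 is cyano in place of bromo on an aromatic carbon. Among the measured compounds shown here, no measured step isolates this change. For the measured compounds named here, the only measured step, from compound 1 to compound 3, concerns another part of the core and says nothing of it. Compound 1 and compound 2 carry the same exchange at the same place but also differ elsewhere on the core, so their numbers give no more than a loose indication: compound 1 gives 14 uL/min and compound 2 gives 36 uL/min, the cyano-bearing member showing the higher number.

A step of a 1.5-fold higher number from compound 3 to compound 4 (0.17 log units; within the scatter) is therefore expected for compound 4, upward but uncertain. Compound 4 is estimated at 25 uL/min, with a range from 12 uL/min to 50 uL/min.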

Compound 4, intrinsic clearance in a liver preparation (reported as CLH), per the amount of preparation that the assay uses: 20 uL/min
Estimate against measurement, compound 4: 1.3-fold (0.10 log units) above; the range from low to high includes it.
By their numbers in this assay, from the lowest: compounds 1, 3, 4 and 2 (each within the scatter of the next, the first and the last beyond it).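

Cyano in place of bromo on this aromatic carbon, part of a fused system of two rings, can now be read alone in this assay: the step is a 1.2-fold higher number from compound 3 to compound 4 (0.07 log units; within the scatter) and the two compounds cannot be told apart, so with methylsulfanyl on both sides of the exchange the read-out does not separate bromo from cyano at this position. The neighbouring exchange, methylsulfanyl in place of methoxy on an aromatic carbon with cyano held fixed, gives a 1.8-fold lower number from compound 2 to compound 4 (0.26 log units; within the scatter) and also stays inside the scatter, so neither single exchange shown accounts on its own for a clear separation in clearance. Nothing measured here offers an explanation for either step.

On these data alone, the series shows only bromo and cyano at this aromatic carbon, so how a primary amine, a carboxylic acid or a longer chain such as propyl would read there remains open. Among these compounds, also open is whether cyano and bromo would stay equally close with methoxy and ethoxy on the other aromatic ring, the pairing of compound 1, since that exchange has no matched step here.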